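The source may hold more compounds than are shown below. What is called first, only, known or untested is meant among the compounds shown, and "the series" means these compounds.

Measured in a functional assay on A549 cells (Homo sapiens) for inhibition, read by MTT assay, with a stated time of 72 h; on this read-out lower numbers stand for stronger inhibition and higher numbers for weaker inhibition:
Compound 1 `CC1=NN(c2ccccc2)C(=O)[C@@]12C(=O)C=CC[C@@H]2c1ccc(C)cc1`: 6570 nM
Compound 2 `CC1=NN(c2ccccc2)C(=O)[C@]12C(=O)C=CC[C@@H]2c1ccc(C)cc1`: 8600 nM

Among the compounds with values here, on these numbers, compound 1 stands level with compound 2, its only measured neighbour: a 1.3-fold higher number from compound 1 to compound 2 (0.12 log units; within the scatter). Within the data shown here, that is the only measured step, and it concerns (the fact that compounds 1 and 2 differ only in the configuration as drawn), so it says nothing about replacing a group.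

Compound 3 `COc1ccccc1[C@H]1CC=CC(=O)[C@@]12C(=O)N(c1ccccc1)N=C2C` makes just such a replacement: 2-methoxyphenyl in place of 4-methylphenyl on a saturated ring carbon. It carries 2-methoxyphenyl in place of 4-methylphenyl on a saturated ring carbon. Among the measured compounds shown here, no measured pair tests this change, so the data offer no direction for it. The starting point therefore remains compound 1 at 6570 nM, with a wide margin on either side. The expected size is no more than the scatter, as an estimated 1.0-fold lower number from compound 1 to compound 3 (0.00 log units; within the scatter). For compound 3 the estimate is 6500 nM, with an expected range of 2200 nM to 19000 nM.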

Compound 3, half-maximal inhibitory concentration: 18700 nM
Estimate against measurement, compound 3: 2.9-fold (0.46 log units) below, and the stated range covers the measured number.
By their numbers in this assay, from the lowest: compounds 1 and 2 (each within the scatter of the next); then compound 3.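

In this assay, replacing 4-methylphenyl with 2-methoxyphenyl on the saturated ring carbon gives a 2.8-fold higher number from compound 1 to compound 3 (0.45 log units; beyond the scatter) and so weaker inhibition, which shows that the group at this position can shift the read-out, if only modestly. This goes further than compounds 1 and 2, whose difference in drawn configuration stays within the scatter, though it rests on a single pair in which the methyl group is lost, a methoxy group enters and the substituent's place on the phenyl ring also changes. Nothing measured here gives a reason for this step.

On these data alone, it remains open whether the methoxy group itself or its place on the phenyl ring matters more. Also open, as far as these compounds go, are how an amine or a carboxylic acid on that phenyl ring would read, and whether configuration matters as little with 2-methoxyphenyl.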